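The source may report more compounds than this note shows. Statements on the series, on what has been measured and on what is new or still open speak of the compounds shown alone.

In an in vitro assay on SH-SY5Y cells for displacement of a labelled ligand from Neuronal acetylcholine receptor; alpha3/beta4 (Homo sapiens) (on this read-out higher numbers stand for weaker inhibition and lower numbers for stronger inhibition), compound 3 `C1=C(c2cccnc2)CC2CNCC1C2` gives 12 nM, the lowest number among the three measured compounds. Compound 1 `Fc1ccc(C2=CC3CNCC(C2)C3)cn1` gives 28 nM, and compound 2 `C1=C(c2cncnc2)CC2CNCC1C2` gives 58 nM. Within the data shown here, the only one-place step measured so far is a 2.3-fold lower number from compound 1 to compound 3 (0.37 log units; beyond the scatter), which went with hydrogen in place of fluoro on an aromatic carbon of the pyridine-type ring.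

Compound 4 `Clc1cncc(C2=CC3CNCC(C2)C3)c1` differs from compound 3 by chloro in place of hydrogen on an aromatic carbon. The earlier step bears on this only loosely, because a 2.3-fold lower number from compound 1 to compound 3 (0.37 log units; beyond the scatter) concerns fluoro rather than chloro, and the chloro of compound 4 sits two atoms from the ring nitrogen. That step showed that taking a fluoro off the ring lowered the number modestly, so putting a chloro on might raise it by a similar or smaller amount, or leave it within the scatter. Compound 4 is therefore expected to give about 20 nM, in a range from 7 nM to 60 nM. The expected step of a 1.7-fold higher number from compound 3 to compound 4 (0.22 log units; within the scatter) is small, and it may well fall within the scatter.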

Compound 4, inhibition constant: 40 nM
Compound 4: middle estimate off by 2.0-fold (0.30 log units), on the low side; measured number inside the range.
By their numbers in this assay, from the lowest: compound 3; then compounds 1, 4 and 2 (each within the scatter of the next, the first and the last beyond it).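

On an aromatic carbon two atoms from the ring nitrogen, chloro in place of hydrogen goes with a 3.3-fold higher number from compound 3 to compound 4 (0.52 log units; beyond the scatter) in this assay, meaning weaker inhibition on this read-out. Among these compounds, until now, the only halogen step was the one with fluoro, a 2.3-fold lower number from compound 1 to compound 3 (0.37 log units; beyond the scatter), so this shows that a second halogen, at this ring carbon, also goes with a higher number than hydrogen in compound 3. Nothing available explains why this step goes the way it does.

Going by these compounds, whether the rise belongs to chloro itself or to any group on this carbon stays open, and a methyl, a methoxy or an amine there would help to separate the two. On these data alone, how fluoro would behave on this same carbon also remains unknown.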